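The source may report more compounds than this note shows. Statements on the series, on what has been measured and on what is new or still open speak of the compounds shown alone.

Measured compounds:
- compound 1, `Clc1ccc(-c2cc(-c3ccoc3)cc(-c3ccc(Cl)s3)n2)cc1`, gives 29500 nM in a functional assay on DU-145 cells (Homo sapiens) for cytotoxicity, read by ELISA, with a stated time of 4 days; a higher number here means a weaker inhibitor, a lower number a stronger inhibitor
- compound 2, `Clc1ccc(-c2cc(-c3ccoc3)cc(-c3cccnc3)n2)s1`, gives 18500 nM in this assay
- compound 3, `Cc1ccsc1-c1cc(-c2ccc(Cl)o2)cc(-c2ccc(Cl)cc2)n1`, gives 21900 nM in this assay

All three measured compounds sit in a similar range in this assay. Compound 3 stands between the other two, and its gaps to compound 2 and to compound 1 are within the scatter, so no order can be read among them.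

One change has been made once already and is now made a second time. From compound 1 to compound 2 the change is pyridin-3-yl in place of 4-chlorophenyl on an aromatic carbon, and it produced a 1.6-fold lower number from compound 1 to compound 2 (0.20 log units; within the scatter). The new compound, compound 4, `Cc1ccsc1-c1cc(-c2ccc(Cl)o2)cc(-c2cccnc2)n1`, arises from compound 3 by pyridin-3-yl in place of 4-chlorophenyl on an aromatic carbon. This is the same kind of change, but not the same: in compound 1 the place is meta to a 5-chlorothiophen-2-yl group and meta to a furan-3-yl group, while in compound 3 it is meta to a 3-methylthiophen-2-yl group and meta to a 5-chlorofuran-2-yl group. How the core of compound 1 and the core of compound 3 differ is not broken down here.

Because the earlier step was a 1.6-fold lower number from compound 1 to compound 2 (0.20 log units; within the scatter), the step from compound 3 to compound 4 is expected to be of similar size, that is a 1.6-fold lower number from compound 3 to compound 4 (0.19 log units; within the scatter), and to stay within the scatter. Compound 4 is therefore estimated at 14000 nM in this assay, with a likely range from 6000 nM to 35000 nM.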

Compound 4, half-maximal inhibitory concentration: 30800 nM
Compound 4: the middle estimate sits 2.2-fold (0.34 log units) below what was measured; the measured number falls inside the stated range.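

In this assay, pyridin-3-yl in place of 4-chlorophenyl gives a 1.4-fold higher number from compound 3 to compound 4 (0.15 log units; within the scatter), and on the other core the same change gave a 1.6-fold lower number from compound 1 to compound 2 (0.20 log units; within the scatter). Neither step can be told apart from no change at all, and setting them side by side reveals no real difference between the two cores: the same change on two cores in this assay, a 1.6-fold lower number (0.20 log units; within the scatter) from compound 1 to compound 2 and a 1.4-fold higher number (0.15 log units; within the scatter) from compound 3 to compound 4, 2.2-fold (0.35 log units) apart, within the scatter of two such steps. So, as far as these four compounds show, this swap carries from one core to the other without a readable effect on the number, but that does not prove that the two cores respond identically, since a small true effect on either core, or a small difference between them, could be hidden in the scatter.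

For the compounds shown here, with only two pairs, both resting on the same swap, it stays open whether the swap would behave the same way on any further core. Also open, as far as these compounds go, is whether a different group at the same place next to the ring nitrogen, such as an amine, a carboxylic acid or a longer chain, would move the number in this assay by more than the scatter.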